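Replacing a trifluoromethylphenyl with pyridinyl: expected cytotoxicity

The source may hold more compounds than are shown below. What is called first, only, known or untested is meant among the compounds shown, and "the series" means these compounds.

Measured so far:
compound 1, `CC(=O)N1CCC(C(=O)N(CCCN2CCN(Cc3ccc(C(F)(F)F)cc3)CC2)c2ccc(C)c(Cl)c2)CC1`: 30500 nM
compound 2, `CC(=O)N1CCC(C(=O)N(CCCN2CCC(Oc3ccccc3)CC2)c2ccc(C)c(Cl)c2)CC1`: > 56600 nM

In an ADME assay (Homo sapiens) for cytotoxicity (a higher number here means that more compound is tolerated, a lower number that less compound is tolerated), compound 1 gives 30500 nM. Within the data shown here, compound 1 holds the only number in this set. For compound 2 the recorded value, > 56600 nM, is a limit of the assay rather than a number. Compound 2 therefore sits at the limit of > 56600 nM in this assay, at which 1 of the 2 values shown sits. Compound 3, `CC(=O)N1CCC(C(=O)N(CCCN2CCN(Cc3ccncc3)CC2)c2ccc(C)c(Cl)c2)CC1`, has not yet been measured. It differs from compound 1 in one place: pyridin-4-yl in place of 4-(trifluoromethyl)phenyl on a saturated chain carbon bound to an amine nitrogen in a ring. Among the measured compounds shown here, no step between measured compounds is available, so the expected direction rests on the structures alone. A modest rise in tolerated concentration is expected, at the edge of the usual scatter rather than clearly beyond it, and a result reported only as a limit is quite possible. Compound 3 is estimated at 50000 nM, with a range from 25000 nM to 100000 nM. The expected step is a 1.6-fold higher number from compound 1 to compound 3 (0.21 log units; within the scatter).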

Compound 3, half-maximal cytotoxic concentration: > 56700 nM
Compound 3: a limit, no number (the forecaster's own chance of this, stated with the estimate: 40%); at least 1.1-fold (0.05 log units) between middle value and limit.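

Among these compounds, compound 1 and compound 3 form the first pair in this set that differs in one place, so the change on a saturated chain carbon bound to an amine nitrogen in a ring can now be read directly. In this assay, pyridin-4-yl in place of 4-(trifluoromethyl)phenyl gives an at least 1.8-fold higher number from compound 1 to compound 3 (0.26 log units; that floor lies within the scatter), so the pair shows no loss of tolerance, but it cannot establish a gain. The reading for compound 3 is a limit of the assay and not a number: the limit of > 56700 nM in this assay, at which 1 of the 3 values shown sits.

On these data alone, how far the true value of compound 3 lies past that limit stays open. The pair also cannot separate the removal of the trifluoromethyl group from the entry of the ring nitrogen, a question that an unsubstituted phenyl or a pyridin-3-yl group at this position could address.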